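The source may hold more compounds than are shown below. What is called first, only, known or untested is meant among the compounds shown, and "the series" means these compounds.

Compound 3 `CC(=O)c1ccc(-c2cn3ccnc3c(-c3ccc4ncn(C5CCCCC5)c4c3)n2)cc1` gives 6.34% in a functional assay on Hs-578T cells (Homo sapiens) for inhibition, read by sulforhodamine B assay, with a stated time of 48 h, tested at 10 uM (a higher number here means more inhibition at the concentration tested (going by the name of the read-out), a lower number less inhibition), the highest of the three numbers measured, though all three lie within the scatter of one another: compound 2 `c1cn2cc(-c3ccsc3)nc(-c3ccc4ncn(C5CCCCC5)c4c3)c2n1` gives 5.56% and compound 1 `c1ccc2c(-c3cn4ccnc4c(-c4ccc5ncn(C6CCCCC6)c5c4)n3)cccc2c1` gives 3.62%. Compound 4 `COc1ccccc1-c1cn2ccnc2c(-c2ccc3ncn(C4CCCCC4)c3c2)n1` differs from compound 3 by 2-methoxyphenyl in place of 4-acetylphenyl on an aromatic carbon. The measured steps that bear on such an exchange of one aromatic group on that aromatic carbon are a number 2.7 percentage points higher from compound 1 to compound 3 (within the scatter) and a number 0.8 percentage points higher from compound 2 to compound 3 (within the scatter), together with a number 1.9 percentage points higher from compound 1 to compound 2 (within the scatter); none of them leaves the scatter. Compound 4 is therefore expected to show no step beyond the scatter, the estimated step being a number 0.8 percentage points lower from compound 3 to compound 4 (within the scatter). The estimate for compound 4 is 5.5%, with a range from 0% to 13%.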

Compound 4, a percentage reported as inhibition, at one concentration (the size of the read-out at that concentration, not a potency): 15.8%
For compound 4 the middle estimate is 10.3 percentage points below the measured one, outside the stated range (above it).
By their numbers in this assay, from the lowest: compounds 1, 2, 3 and 4 (each within the scatter of the next, the first and the last beyond it).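

In this assay, among these compounds, 2-methoxyphenyl is the first group on this aromatic carbon to give steps beyond the scatter, modest ones, with a number 10.2 percentage points higher from compound 2 to compound 4 (beyond the scatter) and a number 12.2 percentage points higher from compound 1 to compound 4 (beyond the scatter), while a number 9.5 percentage points higher from compound 3 to compound 4 (within the scatter) stays within it. The position therefore responds to the group it carries, although compound 4 is not separated from compound 3. Nothing available explains this result. The compounds shown leave open whether the methoxy group itself matters, and whether an unsubstituted phenyl, or an amine in place of the methoxy, would give a number like that of compound 4.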